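Cyclopropane aryl replacement in a GPR88 agonist series

The compounds below may be only part of what the source reports. "The series", "measured", "known", "first", "only" and "open" are said of these compounds alone.

Measured compounds:
compound 1 `CC[C@H](C)[C@@H](CN(C(=O)[C@@H]1C[C@H]1c1ccccc1)c1ccc(-c2ccccc2)cc1)NC(C)=O`: 5.8 nM
compound 2 `CC(C)C[C@H](N)CCN(C(=O)[C@@H]1C[C@H]1c1ccccc1)c1ccc(-c2ccccc2)cc1`: 3 nM
compound 3 `CC[C@H](C)[C@H](N)CN(C(=O)[C@@H]1C[C@H]1c1ccc(Cl)cc1)c1ccc(-c2ccccc2)cc1`: 4300 nM

Working notes. In a functional assay for agonist activity at G protein-coupled receptor 88 (Homo sapiens), read by HTRF and cAMP accumulation (a lower number here means that less compound is needed, a higher number that more compound is needed for the effect), compound 3 gives 4300 nM, the highest of the three numbers; compound 1 gives 5.8 nM and compound 2 gives 3 nM, both well beyond the scatter from compound 3. Among the compounds with values here, the only single-point step available, a 1.9-fold lower number from compound 1 to compound 2 (0.29 log units; within the scatter), concerns the chain on the amide-type nitrogen and is within the scatter; it says nothing about the group on the three-membered ring. Compound 3 differs from compound 1 and compound 2 in more than one place, so its values alone cannot be split into a chain part and a ring part.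

Compound 4 `CC[C@H](C)[C@H](N)CN(C(=O)[C@@H]1C[C@H]1C1CCCCC1)c1ccc(-c2ccccc2)cc1` is compound 3 with cyclohexyl in place of 4-chlorophenyl on a saturated ring carbon. Within the data shown here, no measured pair isolates a change of this kind, so no direction can be read from the data; the expectation has to stay close to compound 3, with wide room either way. The step is expected to be a 1.2-fold lower number from compound 3 to compound 4 (0.09 log units; within the scatter), i.e. no clear movement beyond the scatter. Compound 4 is therefore estimated at 3500 nM, with a likely range from 800 nM to 15000 nM.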

Compound 4, half-maximal effective concentration: > 25000 nM
Compound 4: no number, only a limit; the forecaster's own chance of this, stated with the estimate: 15%; at least 7.1-fold (0.85 log units) between middle value and limit.
By their numbers in this assay, from the lowest: compounds 2 and 1 (each within the scatter of the next); then compound 3. At a limit, above all of these: compound 4.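

In this assay compound 4 gives > 25000 nM, which is a limit of the assay and not a number: the limit of > 25000 nM in this assay, at which 1 of the 4 values shown sits. Cyclohexyl in place of 4-chlorophenyl on a saturated ring carbon gives an at least 5.8-fold higher number from compound 3 to compound 4 (0.76 log units; beyond the scatter), so the group on the three-membered ring does move the read-out, which no earlier pair could show, and the true size of the step stays open at this limit. The counted hydrogen-bond donors, acceptors and charge stay the same, so the step goes with a non-aromatic ring replacing an aromatic one and the loss of the chlorine together, and these two differences cannot be separated here, starting from compound 3 at 4300 nM.

Compound 3 differs from compound 1 and compound 2 in more than one place, so the part of its distance from them that belongs to the chlorine and the part that belongs to the chain remain unsplit. Also open, going by these compounds, is how a 4-fluorophenyl or a pyridyl group would read at this position, and whether cyclohexyl gives the same result on the chains of compound 1 and compound 2.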